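Swapping fluorine for chlorine on the sulfonyl aryl ring

The compounds below may be only part of what the source reports. "The series", "measured", "known", "first", "only" and "open" are said of these compounds alone.

Measured so far:
Compound 1, `CC1CCN(c2c(S(=O)(=O)c3cc(Cl)cc(Cl)c3)cnc3ccc(Cl)cc23)CC1`: 88%
Compound 2, `COc1ccc2ncc(S(=O)(=O)c3cc(F)cc(F)c3)c(N3CCC(C)CC3)c2c1`: 30%

In an assay on isolated protein for displacement of a labelled ligand from metabotropic glutamate receptor 5 (Homo sapiens), with a stated time of 60 min, tested at 1 uM (a lower number here means less inhibition, a higher number more inhibition at the concentration tested (going by the name of the read-out)), compound 1 gives 88%. Compound 2 stands lowest of the two numbers in this assay, where compound 2 gives 30%, a gap to compound 1 that lies beyond the scatter; the two differ in more than one place, so their values alone can be compared. Compound 3, `COc1ccc2ncc(S(=O)(=O)c3cc(Cl)cc(Cl)c3)c(N3CCC(C)CC3)c2c1`, has not been measured. It differs from compound 2 in one respect: 3,5-dichlorophenyl in place of 3,5-difluorophenyl on a sulfonyl sulfur. Compound 3 thus carries the same sulfonyl aryl group as compound 1 while keeping the core of compound 2. Among the compounds with values here, no single-change step is available to calibrate this swap, so the expectation rests on the two values shown. The step from compound 2 to compound 3 is expected to be an increase, a number 30 percentage points higher from compound 2 to compound 3 (beyond the scatter), because compound 1 with the 3,5-dichlorophenyl group gives 88%. Compound 3 is therefore estimated at 60%, with a range from 35% to 85%.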

Compound 3, a percentage reported as inhibition, at one concentration (the size of the read-out at that concentration, not a potency): 87%
Beside the measured number, compound 3's estimate is 27 percentage points below it; the whole stated range lies below it.
By their numbers in this assay, from the lowest: compound 2; then compounds 3 and 1 (each within the scatter of the next).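

Within the data shown here, with the core of compound 2 held fixed, the first single-change reading at this position in this assay shows that 3,5-dichlorophenyl in place of 3,5-difluorophenyl on a sulfonyl sulfur gives a number 57 percentage points higher from compound 2 to compound 3 (beyond the scatter), so the identity of this aryl group alone can move the read-out by a large step. With the 3,5-dichlorophenyl group in place, methoxy in place of chloro on an aromatic carbon gives a number 1 percentage points lower from compound 1 to compound 3 (within the scatter), so that change does not separate the two compounds in this assay. Nothing available explains why the chlorine-bearing ring reads so differently from the fluorine-bearing one.

The compounds shown leave open how a plain phenyl, a 3,5-dibromophenyl or a 3,5-dimethylphenyl group would read on the same sulfonyl sulfur. They also leave open whether the 3,5-difluorophenyl group gives a step of similar size on the core of compound 1.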